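Replacing a chloro with a methyl on the aniline ring

The source may hold more compounds than are shown below. What is called first, only, known or untested is meant among the compounds shown, and "the series" means these compounds.

The compounds share one core and differ only in the ring attached to the amine nitrogen. Compound 1 `FC(F)(F)c1ccc(CSc2nc(Nc3ccccc3Cl)c3ccccc3n2)cc1` carries a 2-chlorophenyl group, and in a functional assay on MDA-MB-231 cells (Homo sapiens) for cytotoxicity, read by MTT assay, with a stated time of 72 h (on this read-out lower numbers stand for stronger inhibition and higher numbers for weaker inhibition), compound 1 gives only a limit, > 50000 nM, not a number. Compound 2 `FC(F)(F)c1ccc(CSc2nc(Nc3cccc(Cl)c3)c3ccccc3n2)cc1` carries a 3-chlorophenyl group and in this assay compound 2 gives 18000 nM. Compound 3 `FC(F)(F)c1ccc(CSc2nc(Nc3ccc(Cl)cc3)c3ccccc3n2)cc1` carries a 4-chlorophenyl group and in this assay compound 3 gives 15100 nM. Moving the chloro gave an at least 2.7-fold lower number from compound 1 to compound 2 (0.44 log units; beyond the scatter) and an at least 3.3-fold lower number from compound 1 to compound 3 (0.51 log units; beyond the scatter), while a 1.2-fold lower number from compound 2 to compound 3 (0.08 log units; within the scatter) kept compounds 2 and 3 within the scatter of each other. Compound 3 therefore sits at the low end of the numbers shown, alongside compound 2.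

Compound 4 `Cc1ccc(Nc2nc(SCc3ccc(C(F)(F)F)cc3)nc3ccccc23)cc1` changes the same ring: methyl in place of chloro on an aromatic carbon. For the measured compounds named here, none of the measured steps swaps one group for another at this place; they only move the chloro, and the two with the group para to the amine nitrogen's position already read alike. The expectation for compound 4 is therefore a step of a 1.0-fold lower number from compound 3 to compound 4 (0.00 log units; within the scatter), within the scatter, giving an estimated 15000 nM in this assay, between 6000 nM and 40000 nM.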

Compound 4, half-maximal inhibitory concentration: > 50000 nM
Compound 4: a limit, no number (the forecaster's own chance of this, stated with the estimate: 15%); middle value at least 3.3-fold (0.52 log units) away from the limit.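

Until now only the position of the chloro had changed. Here the group itself changes at one place, and in this assay methyl in place of chloro gives an at least 3.3-fold higher number from compound 3 to compound 4 (0.51 log units; beyond the scatter). The 4-methylphenyl group also compares unfavourably with the 3-chlorophenyl group, with an at least 2.7-fold higher number from compound 2 to compound 4 (0.44 log units; beyond the scatter), so at this place the identity of the group matters as well as its position, even though the heavy-atom count stays the same. Compound 1 and compound 4 both end in a limit, so the step between them cannot be read: the limit of > 50000 nM in this assay, at which 2 of the 4 values shown sit.

On these data alone, how far the true value of compound 4 lies past its limit remains unknown. Only chloro and methyl appear at this place, so a fluoro, a methoxy or an amine there could show whether chloro is unusual or methyl is.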